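Nitroimidazole-linked oxadiazoles on MCF7 cells: a ring swap

The compounds below may be only part of what the source reports. "The series", "measured", "known", "first", "only" and "open" are said of these compounds alone.

Measured so far:
- compound 1, `CCOc1ccccc1-c1nnc(SCCn2c([N+](=O)[O-])cnc2C)o1`: 25900 nM
- compound 2, `Cc1ncc([N+](=O)[O-])n1CCSc1nnc(-c2ccccc2Cl)o1`: 22500 nM

Both compounds were tested in a functional assay on MCF7 cells (Homo sapiens) for cytotoxicity, read by MTT assay, with a stated time of 48 h; on this read-out higher numbers stand for weaker inhibition and lower numbers for stronger inhibition. Compound 2 has the lowest of the two numbers, but its nearest neighbour, compound 1, differs from it by a 1.2-fold lower number from compound 1 to compound 2 (0.06 log units; within the scatter), so on these numbers the two compounds cannot be told apart. Among the measured compounds shown here, that single step, a chloro in place of ethoxy on an aromatic carbon, is the only measured change available.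

Compound 3, `Cc1ncc([N+](=O)[O-])n1CCSc1nnc(-c2cnccc2N)o1`, is the next compound to be tested. Its difference from compound 2 is 4-aminopyridin-3-yl in place of 2-chlorophenyl on an aromatic carbon. For the measured compounds named here, no measured step touches this kind of change: the one step known, from compound 1 to compound 2, swaps one group for another on the same carbon ring and stays within the scatter, which says nothing about replacing the whole ring. In the absence of a bearing step, the expectation for compound 3 in this assay is a value near that of compound 2, with a step of a 1.1-fold higher number from compound 2 to compound 3 (0.05 log units; within the scatter), and a wide range. Compound 3 is therefore estimated at 25000 nM, between 8000 nM and 80000 nM.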

Compound 3, half-maximal inhibitory concentration: 29300 nM
Beside the measured number, compound 3's estimate is 1.2-fold (0.07 log units) below it; the measured number falls inside the stated range.
By their numbers in this assay, from the lowest: compounds 2, 1 and 3 (each within the scatter of the next).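

This position on the five-membered aromatic ring tolerates more than a swap of one group on the same carbon ring: in this assay, replacing the entire 2-chlorophenyl with 4-aminopyridin-3-yl gives a 1.3-fold higher number from compound 2 to compound 3 (0.11 log units; within the scatter). The exchange is a substantial one, although the heavy-atom count stays the same: a ring of carbon only leaves, with 0 hydrogen-bond donors and 0 hydrogen-bond acceptors, and a ring with 1 hetero atom enters, with 1 hydrogen-bond donor and 2 hydrogen-bond acceptors. Even so, compound 2 and compound 3 cannot be told apart on these numbers, and no supporting measurement here bears on what lies behind this result.

Both steps read at this position stay within the scatter, so neither shows a group that clearly moves the number in this assay. Still open, as far as these compounds go, is whether a different kind of group on this same aromatic carbon, such as a saturated piperidine ring or a phenyl ring carrying a carboxylic acid, would produce a step beyond the scatter.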